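The source may report more compounds than this note shows. Statements on the series, on what has been measured and on what is new or still open speak of the compounds shown alone.

The measured compounds:

compound 1, `COc1cc2c(Oc3ccc(NC(=O)c4nn(-c5ccccc5OC(F)(F)F)c(=O)cc4C)cc3F)ccnc2cc1OCCCN1CCCC1`, with 180 nM in a functional assay on HT-29 cells (Homo sapiens) for inhibition, read by MTT assay, with a stated time of 72 h; on this read-out higher numbers stand for weaker inhibition and lower numbers for stronger inhibition
compound 2, `COc1cc2c(Oc3ccc(NC(=O)c4nn(-c5ccccc5OC(F)(F)F)c(=O)cc4C)cc3F)ccnc2cc1OCCCN1CCN(C)CC1`, with 180 nM in this assay

Compound 2 stands level with compound 1 at the digits shown, the single measured step being no change at the digits printed from compound 1 to compound 2 (within the scatter), a change at the amine end of the chain that lies within the scatter.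

Compound 3, `COc1cc2c(Oc3ccc(NC(=O)c4nn(-c5ccc(F)c(F)c5)c(=O)cc4C)cc3F)ccnc2cc1OCCCN1CCN(C)CC1`, differs from compound 2 at the other end of the molecule: 3,4-difluorophenyl in place of 2-(trifluoromethoxy)phenyl on an aromatic nitrogen. Within the data shown here, no measured step bears on this position. Among the measured compounds shown here, the only step in hand, no change at the digits printed from compound 1 to compound 2 (within the scatter), concerns the amine on the chain and gives no guide to what an exchange of the aryl group on the aromatic nitrogen may do. With nothing to argue for a shift in either direction, the default expectation for compound 3 is a value close to that of compound 2, held with low confidence and therefore with a wide range.

Compound 3 is thus expected to give about 250 nM in this assay, somewhere between 60 nM and 1000 nM. This estimate means a step of a 1.4-fold higher number from compound 2 to compound 3 (0.14 log units; within the scatter), which is expected to stay within the scatter.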

Compound 3, half-maximal inhibitory concentration: 170 nM
Estimate against measurement, compound 3: 1.5-fold (0.17 log units) above; the range from low to high includes it.
By their numbers in this assay, from the lowest: compounds 3, 1 and 2 (each within the scatter of the next).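

In this assay, among these compounds, the first measured step at this position, the exchange of 2-(trifluoromethoxy)phenyl for 3,4-difluorophenyl on the aromatic nitrogen, gives a 1.1-fold lower number from compound 2 to compound 3 (0.02 log units; within the scatter) and so leaves the reading level. The earlier compounds shown here spoke only to the amine at the end of the chain, whereas this pair shows that the aryl group at the other end of the molecule can also be exchanged with no step beyond the scatter, even though the entering group has fewer heavy atoms and fewer hydrogen-bond acceptors. No measurement at hand explains why the two aryl groups read alike.

From the compounds shown here alone, whether this level reading extends to an unsubstituted phenyl, a pyridine ring, a nitrile-bearing phenyl or a small alkyl group such as methyl on that nitrogen remains open, since two aryl groups cannot show how far the position tolerates change. Going by these compounds, it is also open whether 3,4-difluorophenyl would read the same when paired with pyrrolidin-1-yl or with a morpholine at the end of the chain, so any independence of the two ends is untested.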